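The source may report more compounds than this note shows. Statements on the series, on what has been measured and on what is new or still open speak of the compounds shown alone.

Working notes on the series. The shared core of compound 1 `Nc1nc(NCc2ccccc2)nc(-c2ccc(F)cc2CO)n1` is kept throughout; compound 2 `Nc1nc(NCc2cccc(F)c2)nc(-c2ccccc2CO)n1` and compound 3 `Nc1nc(NCc2cccc(C(F)(F)F)c2)nc(-c2ccccc2CO)n1` vary the group on the saturated chain carbon bound to a nitrogen on the aromatic ring. In a functional assay on cells for positive allosteric modulation of G-protein coupled receptor 68 (Homo sapiens), read by a luciferase reporter and cAMP accumulation, with a stated time of 30 min, at pH 6.8 and pH 8.3, in the presence of a further agent that is not named here (on this read-out lower numbers stand for lower potency and higher numbers for higher potency (the scale is a negative logarithm)), compound 1 gives 4.58, compound 2 gives 4.52 and compound 3 gives 5.11. Compound 2 and compound 1 lie within the scatter of each other; against compound 3 compound 2 sits lower by a margin beyond the scatter. For the measured compounds named here, the one single-point step measured is a number 0.59 log units higher from compound 2 to compound 3 (beyond the scatter), trifluoromethyl in place of fluoro on an aromatic carbon.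

Compound 4 `Cc1ccccc1CNc1nc(N)nc(-c2ccccc2CO)n1` differs from compound 2 by 2-methylphenyl in place of 3-fluorophenyl on a saturated chain carbon bound to a nitrogen on an aromatic ring. Going by the values given here, no measured step covers this change; the step from compound 2 to compound 3 swaps one group for another at the same place and does not tell how moving and changing the group acts here. In this assay the expected step is therefore a number 0.18 log units higher from compound 2 to compound 4 (within the scatter), not beyond the scatter. Compound 4 is estimated at 4.7, with a range from 4.2 to 5.3.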

Compound 4, negative logarithm of the antagonist equilibrium constant: 4.7
Compound 4: the middle estimate sits on the measured number at the digits printed; measured number inside the range.
By their numbers in this assay, from the lowest: compounds 2, 1 and 4 (each within the scatter of the next); then compound 3.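

Putting 2-methylphenyl in place of 3-fluorophenyl on a saturated chain carbon bound to a nitrogen on an aromatic ring gives a number 0.18 log units higher from compound 2 to compound 4 (within the scatter) in this assay. For the compounds shown here, this place therefore holds a ring of carbon only, with no fluorine on it, and the number stays within the scatter of that of compound 2, while compound 3 at 5.11 still carries the only step here that lies beyond the scatter. Nothing at hand bears on the reason for this result.

Because the two changes alter both the group and where it stands on the ring, the effect of each cannot be separated with the compounds shown. As far as these compounds go, how an amine, a carboxylic acid or a longer chain would read in the same place also stays open.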